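The compounds below may be only part of what the source reports. "The series", "measured", "known", "first", "only" and "open" are said of these compounds alone.

Compound 1, `CCCCCCCCCCCCCCNC(=O)[C@@H](NS(=O)(=O)c1ccc(C)cc1)[C@@H](C)O`, and compound 2, `CCCCCCCCCCCCCCNC(=O)[C@@H](NS(=O)(=O)c1cccs1)[C@@H](C)O`, share a core and differ only in the group on the sulfonyl sulfur. In a functional assay on MCF7 cells (Homo sapiens) for cytotoxicity, read by MTT assay, with a stated time of 48 h (a lower number here means a stronger inhibitor, a higher number a weaker inhibitor), compound 1 gives 12900 nM, and compound 2 gives 18700 nM. The change between them is thiophen-2-yl in place of 4-methylphenyl on a sulfonyl sulfur and it gave a 1.4-fold higher number from compound 1 to compound 2 (0.16 log units; within the scatter). Compound 3, `CCCCCCCCCCCCCCCCCCNC(=O)[C@@H](NS(=O)(=O)c1ccc(C)cc1)[C@@H](C)O`, carries a longer chain than compound 1; the difference between the two cores is butyl in place of hydrogen on a saturated chain carbon, ten or more bonds along the chain from an amide-type nitrogen, and it gave a 4.7-fold higher number from compound 1 to compound 3 (0.67 log units; beyond the scatter), so that compound 3 gives 60100 nM in this assay, the highest of the three numbers. Compound 4, `CCCCCCCCCCCCCCCCCCNC(=O)[C@@H](NS(=O)(=O)c1cccs1)[C@@H](C)O`, has not yet been measured. It differs from compound 3 by thiophen-2-yl in place of 4-methylphenyl on a sulfonyl sulfur, at the very same place as in the earlier pair, so this is the same change as from compound 1 to compound 2. Because that earlier step was a 1.4-fold higher number from compound 1 to compound 2 (0.16 log units; within the scatter), the step expected for compound 4 is a 1.4-fold higher number from compound 3 to compound 4 (0.15 log units; within the scatter), again within the scatter. Compound 4 is therefore estimated at 85000 nM in this assay, expected to lie between 40000 nM and 180000 nM.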

Compound 4, half-maximal inhibitory concentration: > 200000 nM
Compound 4 gave a limit, no number; the forecaster's own chance of this, stated with the estimate: 20%; middle value at least 2.3-fold (0.37 log units) from the limit.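

In this assay compound 4 gives a limit of the assay and not a number: > 200000 nM. On the core of compound 3, thiophen-2-yl in place of 4-methylphenyl gives an at least 3.3-fold higher number from compound 3 to compound 4 (0.52 log units; beyond the scatter), yet this does not show that the change carries differently from one core to the other, nor that it carries unchanged: the same change on two cores in this assay, a 1.4-fold higher number (0.16 log units; within the scatter) from compound 1 to compound 2 and an at least 3.3-fold higher number (0.52 log units; beyond the scatter) from compound 3 to compound 4; the limit leaves it open whether they differ The added butyl on the chain, now on the cores with thiophen-2-yl, gives an at least 10-fold higher number from compound 2 to compound 4 (1.02 log units; beyond the scatter), so this change raises the number on both cores, though whether it does so by the same amount is not settled: the same change on two cores in this assay, a 4.7-fold higher number (0.67 log units; beyond the scatter) from compound 1 to compound 3 and an at least 10-fold higher number (1.02 log units; beyond the scatter) from compound 2 to compound 4; the limit leaves it open whether they differ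

Going by these compounds, the true size of both new steps stays open, since compound 4 sits at the limit: the limit of > 200000 nM in this assay, at which 1 of the 4 values shown sits. Also open is how a furan-2-yl on the sulfonyl sulfur, or a chain shorter than that of compound 1, would read in this assay.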